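The compounds below may be only part of what the source reports. "The series", "measured", "known", "first", "only" and "open" are said of these compounds alone.

Working notes on the series. In a functional assay for activation of Alpha-1D adrenergic receptor (Homo sapiens) (a higher number here means that more compound is needed for the effect, a lower number that less compound is needed), compound 1 `Cc1nc(-c2ccccc2NCC2=NCCN2)co1` gives < 5020 nM, which is a limit of the assay and not a number. Compound 2 `c1ccc(-c2cnoc2)c(NCC2=NCCN2)c1` gives in this assay < 100000 nM, again only a limit. Compound 3 `Cc1cccnc1-c1ccccc1NCC1=NCCN1` likewise reaches only a limit, < 100000 nM. Compound 2 therefore stands at the limit of < 100000 nM in this assay, at which 2 of the 3 values shown sit, and the other value shown is the limit of < 5020 nM in this assay, at which 1 of the 3 values shown sits, at which compound 1 sits. Within the data shown here, the only pair that differs in one place gives a step that the two limits leave unreadable from compound 1 to compound 2, so no measured step in the set has a readable size, and compound 3 cannot be placed relative to the other two beyond its own limit.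

Compound 4 `CCO/N=C(\C)c1ccccc1NCC1=NCCN1` is not yet measured in this assay. Its change from compound 2 is a group of 6 heavy atoms (4 carbon, 1 nitrogen, 1 oxygen; no ring) in place of a group of 5 heavy atoms (3 carbon, 1 nitrogen, 1 oxygen; one five-membered aromatic ring with 2 hetero atoms), on an aromatic carbon. Among the measured compounds shown here, the single measured step noted above bears on a related exchange on the same aromatic carbon, but its size is unreadable, so no direction beyond the scatter can be expected in this assay; the most likely outcome is that compound 4 is again reported only as a limit.

Compound 4 is therefore expected in this assay at 20000 nM, with a range from 2000 nM to 100000 nM. The expected step this estimate means is a step that the limit leaves unreadable from compound 2 to compound 4.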

Compound 4, half-maximal effective concentration: < 5020 nM
Compound 4: no number, only a limit; the forecaster's own chance of this, stated with the estimate: 70%; at least 3.9-fold (0.60 log units) between middle value and limit.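

Compound 4 is again reported only as a limit in this assay, so neither the step to it from compound 1 nor the step to it from compound 2 can be read. The compounds shown leave open what actual value any of the four compounds has in this assay, and whether exchanging the group on the aromatic carbon changes that value at all.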